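Fluoro in place of bromo on compound 1

The compounds below may be only part of what the source reports. "The series", "measured", "known", "first", "only" and "open" are said of these compounds alone.

Compound 1 `COc1cc(NC(C)CCCNC(=O)Nc2ccc(Br)cc2)c2ncccc2c1`: 20000 nM
Compound 2 `COc1cc(NC(C)CCCNC(=O)NNC(=O)Nc2ccc(C(F)(F)F)cc2)c2ncccc2c1`: 15000 nM

Both compounds were tested in a functional assay on HeLa cells (Homo sapiens) for inhibition, read by MTT assay, with a stated time of 72 h; on this read-out lower numbers stand for stronger inhibition and higher numbers for weaker inhibition. The reading for compound 1 is 20000 nM, and it lies within the usual scatter of the reading for compound 2 at 15000 nM. The two values therefore give no ranking. The two structures differ in more than one place, so they do not isolate the effect of any single group.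

The next compound, compound 3 `COc1cc(NC(C)CCCNC(=O)Nc2ccc(F)cc2)c2ncccc2c1`, keeps the core of compound 1 and changes one group: fluoro in place of bromo on an aromatic carbon. This places fluoro in place of bromo on an aromatic carbon, para to a large group, turning the 4-bromophenyl into a 4-fluorophenyl. Among the compounds with values here, no measured pair shows what this exchange does in this assay, so the expectation rests on compound 1 alone, at 20000 nM. A small move towards a higher number is expected, probably not far beyond the scatter, and the estimated step is a 1.3-fold higher number from compound 1 to compound 3 (0.10 log units; within the scatter). Compound 3 is expected at 25000 nM, with an estimated range of 10000 nM to 60000 nM.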

Compound 3, half-maximal inhibitory concentration: 20000 nM
Compound 3: the middle estimate sits 1.3-fold (0.10 log units) above what was measured, and the stated range covers the measured number.
By their numbers in this assay, from the lowest: compounds 2, 1 and 3 (each within the scatter of the next).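

Fluoro in place of bromo gives the first comparison in this series that isolates a single place: in this assay, the reading runs no change at the digits printed from compound 1 to compound 3 (within the scatter) and so gives no sign that this exchange matters. On an aromatic carbon para to a large group, the 4-bromophenyl and the 4-fluorophenyl therefore cannot be told apart by this read-out, so the high number of compound 1 does not depend on the bromo group in particular. Nothing available explains why these two halogens read alike.

Within the data shown here, whether this position is equally indifferent to groups of another kind, such as an amine, a carboxylic acid or a methoxy group, remains open, since the only exchange that can be read here is between two halogens. Compound 2 differs from compound 1 and compound 3 in more than one place, so the compounds shown also leave open what the shared core and the chain contribute, and whether any change there, such as a longer chain, would move the reading.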